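The compounds below may be only part of what the source reports. "The series", "measured", "known", "first", "only" and "open" are said of these compounds alone.

Measured so far in an ADME assay on microsomes from liver (Homo sapiens) for metabolic stability; a higher number here means that the compound lasts longer, a lower number that the compound disappears faster:
compound 1, `COc1ccccc1-c1cc(C2=Nc3c(C(C)(C)C)nn(CCCO)c3C(=O)NC2)ccc1OC`: 1.37 h
compound 2, `COc1ccc(C2=Nc3c(C(C)(C)C)nn(CCCO)c3C(=O)NC2)cc1-c1ccccc1SC`: 0.85 h

Compound 2 stands at the level of compound 1, since a 1.6-fold lower number from compound 1 to compound 2 (0.21 log units; within the scatter) lies within the scatter. Compound 3, `COc1ccc(C2=Nc3c(C(C)(C)C)nn(CCCO)c3C(=O)NC2)cc1-c1cnc(N(C)C)cc1C`, carries 6-(dimethylamino)-4-methylpyridin-3-yl in place of 2-(methylsulfanyl)phenyl on an aromatic carbon. Within the data shown here, the only measured step exchanged methoxy for methylsulfanyl and stayed within the scatter; no measured step covers the exchange of a whole aryl group, so the data give little guidance on this change. No step beyond the scatter is therefore expected in this assay. For compound 3 the estimate is 0.9 h, with a range of 0.4 h to 2 h. The expected step is accordingly a 1.1-fold higher number from compound 2 to compound 3 (0.02 log units; within the scatter).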

Compound 3, half-life: 0.7 h
The estimate for compound 3 lay 1.3-fold (0.11 log units) above the measured number, within the range that was stated.
By their numbers in this assay, from the lowest: compounds 3, 2 and 1 (each within the scatter of the next).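

On the aromatic carbon ortho to a methoxy group, this assay now covers the exchange of a whole aryl group: 6-(dimethylamino)-4-methylpyridin-3-yl in place of 2-(methylsulfanyl)phenyl gives a 1.2-fold lower number from compound 2 to compound 3 (0.08 log units; within the scatter) and in place of 2-methoxyphenyl gives a 2.0-fold lower number from compound 1 to compound 3 (0.29 log units; within the scatter). Across these compounds, a ring with one hetero atom replaces a ring of carbon only without a step beyond the scatter. No supporting measurement accounts for this result. On these data alone, it remains open whether a carboxylic acid or a primary amine on this aryl ring would give a step beyond the scatter.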